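The source may hold more compounds than are shown below. What is called first, only, known or untested is meant among the compounds shown, and "the series" means these compounds.

Compound 1 `CCC(CC)O[C@@H]1C=C(C(=O)Nc2ccccc2)C[C@H](N)[C@H]1NC(C)=O`: 151000 nM
Compound 2 `CCC(CC)O[C@@H]1C=C(C(=O)O)C[C@H](NC(=O)OC(C)(C)C)[C@H]1NC(C)=O`: > 1000000 nM

These values come from an ADME assay on MDCK cells (Canis lupus familiaris) for cytotoxicity, with a stated time of 48 h; on this read-out lower numbers stand for higher toxicity in this test and higher numbers for lower toxicity in this test. Compound 2 stands at > 1000000 nM, which is a limit of the assay and not a number. Compound 3 `CCC(CC)O[C@@H]1C=C(C(=O)Nc2ccccc2OC)C[C@H](NC(=O)OC(C)(C)C)[C@H]1NC(C)=O` differs from compound 2 in one place: (2-methoxyphenyl)amino in place of hydroxy on a carbonyl carbon. Among the compounds with values here, no measured pair shows this change. Within the data shown here, the expectation therefore leans on compound 1 , the only compound with a true number, at 151000 nM. A clear move toward lower numbers is expected, with an estimated size of an at least 3.3-fold lower number from compound 2 to compound 3 (0.52 log units; beyond the scatter). For compound 3 the estimated value is 300000 nM, with an expected range of 80000 nM to 900000 nM.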

Compound 3, half-maximal cytotoxic concentration: > 1000000 nM
Compound 3 was reported as a limit; the forecaster's own chance of this, stated with the estimate: 35%; middle value at least 3.3-fold (0.52 log units) from the limit.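

Compound 2 and compound 3 are both reported only as a limit, not a number, so the step between them cannot be read: the limit of > 1000000 nM in this assay, at which 2 of the 3 values shown sit.

The compounds shown leave open whether (2-methoxyphenyl)amino in place of hydroxy on a carbonyl carbon changes the result in this assay at all, and in which direction.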